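This account rests on a few compounds, and the source may have more. Where it says the series, first, only, none or still open, it means among the compounds named here.

Measured compounds:
compound 1 `Cc1ccc(S(=O)(=O)Oc2ccc3c(c2C)[C@H](Cn2cc(-c4ccccn4)nn2)[C@@]24CC(=O)[C@@](C)(CC[C@@H]32)C4)cc1` — > 20000 nM
compound 2 `Cc1c(O)ccc2c1[C@H](Cn1cc(-c3ccccn3)nn1)[C@@]13CC(=O)[C@@](C)(CC[C@@H]21)C3` — > 20000 nM
compound 3 `C=C1C(=O)[C@]23C[C@@]1(O)CC[C@H]2c1ccc(O)c(C)c1[C@@H]3Cn1cc(-c2ccc(F)cc2)nn1` — 850 nM

In a functional assay on SMMC-7721 cells (Homo sapiens) for cytotoxicity, read by MTT assay, with a stated time of 4 days (on this read-out higher numbers stand for weaker inhibition and lower numbers for stronger inhibition), the value for compound 1 is a limit of the assay, not a number. The value for compound 2 in this assay is likewise a limit. Within the data shown here, compound 3 is the only compound with a number; in this assay compound 3 gives 850 nM. How the core of compound 3 differs from the core of compound 2 is not broken down here.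

The change from compound 2 to compound 1 is (4-methylphenyl)sulfonyl in place of hydrogen on an oxygen on an aromatic ring. Its step is a step that the two limits leave unreadable from compound 2 to compound 1, because both ends sit at the limit of > 20000 nM in this assay, at which 2 of the 3 values shown sit.

Compound 4 `C=C1C(=O)[C@]23C[C@@]1(O)CC[C@H]2c1ccc(OS(=O)(=O)c2ccc(C)cc2)c(C)c1[C@@H]3Cn1cc(-c2ccc(F)cc2)nn1` is unmeasured. It differs from compound 3 by (4-methylphenyl)sulfonyl in place of hydrogen on an oxygen on an aromatic ring, the same change at the same place. Since the measured step gives no readable size, the expectation for compound 4 rests only on compound 3 at 850 nM. For compound 4 the expected step is a 1.8-fold higher number from compound 3 to compound 4 (0.25 log units; within the scatter). Compound 4 is estimated at 1500 nM, between 400 nM and 8000 nM.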

Compound 4, half-maximal inhibitory concentration: 4280 nM
Estimate against measurement, compound 4: 2.9-fold (0.46 log units) below; the range from low to high includes it.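

In this assay, hydroxy to ((4-methylphenyl)sulfonyl)oxy gives a 5.0-fold higher number from compound 3 to compound 4 (0.70 log units; beyond the scatter), so on the core of compound 3 the change weakens inhibition while leaving a measurable value. On the core of compound 2 the same step cannot be read, because compound 2 and compound 1 both stand at a limit of the assay and not at a number: the limit of > 20000 nM in this assay, at which 2 of the 4 values shown sit.

The series therefore holds a single readable step for this change, and it does not show whether that size carries from one core to another.

The compounds shown leave open how other groups on an oxygen on an aromatic ring would compare, such as methyl, acetyl or a chain ending in an amine. They also leave open whether any core other than that of compound 3 gives a readable size for this change.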